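Changing the aryl group on the shared core

The compounds below may be only part of what the source reports. "The series", "measured", "known", "first", "only" and "open" are said of these compounds alone.

Among the compounds with values here, compound 3 `COc1cc2c(Oc3ccc(NC(=O)c4nn(-c5ccccc5OC(F)(F)F)c(=O)cc4C)cc3F)ccnc2cc1OCCCN1CCCCC1` gives the lowest of the three numbers so far in a functional assay on MKN-45 cells (Homo sapiens) for inhibition, read by MTT assay, with a stated time of 72 h (on this read-out higher numbers stand for weaker inhibition and lower numbers for stronger inhibition), namely 40 nM. Compound 2 `COc1cc2c(Oc3ccc(NC(=O)c4nn(-c5ccccc5OC(F)(F)F)c(=O)cc4C)cc3F)ccnc2cc1OCCCN1CCCC1` gives 60 nM in this assay, and compound 1 `COc1cc2c(Oc3ccc(NC(=O)c4nn(-c5ccccc5C(F)(F)F)c(=O)cc4C)cc3F)ccnc2cc1OCCCN1CCCCC1` gives 90 nM. The step of a 2.3-fold lower number from compound 1 to compound 3 (0.35 log units; beyond the scatter) concerns the same aryl ring that changes next, whereas the step of a 1.5-fold lower number from compound 2 to compound 3 (0.18 log units; within the scatter) concerns the amine at the far end of the chain. Compound 4 `COc1cc2c(Oc3ccc(NC(=O)c4nn(-c5ccc(Cl)cc5Cl)c(=O)cc4C)cc3F)ccnc2cc1OCCCN1CCCCC1` differs from compound 3 in one place: 2,4-dichlorophenyl in place of 2-(trifluoromethoxy)phenyl on an aromatic nitrogen. Within the data shown here, only the step from compound 1 to compound 3 bears on this change, and it was modest, so no step beyond the scatter is expected in either direction. For compound 4 an estimated 1.5-fold higher number from compound 3 to compound 4 (0.18 log units; within the scatter) is expected, giving 60 nM with a range of 25 nM to 150 nM.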

Compound 4, half-maximal inhibitory concentration: 80 nM
Estimate against measurement, compound 4: 1.3-fold (0.12 log units) below, within the range that was stated.
By their numbers in this assay, from the lowest: compounds 3, 2, 4 and 1 (each within the scatter of the next, the first and the last beyond it).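

In this assay, 2,4-dichlorophenyl on the aromatic nitrogen gives a 2.0-fold higher number from compound 3 to compound 4 (0.30 log units; within the scatter) against the 2-(trifluoromethoxy)phenyl group and a 1.1-fold lower number from compound 1 to compound 4 (0.05 log units; within the scatter) against the 2-(trifluoromethyl)phenyl group. An aryl group carrying chlorine, with neither oxygen nor fluorine, thus stays within the scatter of both earlier aryl groups, even though those two lie beyond the scatter of each other. Nothing available accounts for this result. The compounds shown leave open whether a plain phenyl group or a pyridyl ring on this nitrogen would stay in the same range.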